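This account rests on a few compounds, and the source may have more. Where it says the series, first, only, none or still open, it means among the compounds named here.

Compound 1, `C=C(Br)C(=O)Nc1cccc(-c2cn3nc(-c4ccc(F)cc4)sc3n2)c1`, gives 830 nM.
Compound 2, `C=C(Br)C(=O)Nc1cccc(-c2cn3nc(-c4ccc(OCC)cc4)sc3n2)c1`, gives 1400 nM.
Compound 3, `C=C(Br)C(=O)Nc1cccc(-c2cn3nc(-c4cccs4)sc3n2)c1`, gives 410 nM.

All three numbers come from a functional assay on CCRF-CEM cells (Homo sapiens) for inhibition, read by cell counting, with a stated time of 3 days; a higher number here means a weaker inhibitor, a lower number a stronger inhibitor. Compound 3 stands lowest of the three, with compound 1 nearest and compound 2 furthest. Compound 4, `C=C(Br)C(=O)Nc1cccc(-c2cn3nc(Cc4ccc(OC)cc4)sc3n2)c1`, differs from compound 3 by 4-methoxybenzyl in place of thiophen-2-yl on an aromatic carbon. Within the data shown here, two measured steps bear on this position: a 2.0-fold lower number from compound 1 to compound 3 (0.31 log units; beyond the scatter) and a 3.4-fold lower number from compound 2 to compound 3 (0.53 log units; beyond the scatter). In both, a six-membered carbon-only ring at this position gave a higher number than the thiophen-2-yl group, and 4-methoxybenzyl is again a six-membered carbon-only ring, here with a one-carbon link. A modest rise is therefore expected, roughly back toward compound 2, as a 2.9-fold higher number from compound 3 to compound 4 (0.47 log units; beyond the scatter). Compound 4 is estimated at 1200 nM, within 400 nM to 4000 nM.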

Compound 4, half-maximal inhibitory concentration: 2300 nM
Beside the measured number, compound 4's estimate is 1.9-fold (0.28 log units) below it; the range from low to high includes it.
By their numbers in this assay, from the lowest: compound 3; then compounds 1, 2 and 4 (each within the scatter of the next, the first and the last beyond it).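

Adding a one-carbon link to a six-membered carbon-only ring does not bring back the level of the thiophen-2-yl group, and this is the largest step at this position so far (a 5.6-fold higher number from compound 3 to compound 4 (0.75 log units; beyond the scatter)). Against the directly attached rings the result splits: 4-fluorophenyl differs beyond the scatter (a 2.8-fold higher number from compound 1 to compound 4 (0.44 log units; beyond the scatter)), while 4-ethoxyphenyl stays within it (a 1.6-fold higher number from compound 2 to compound 4 (0.22 log units; within the scatter)). No measurement here explains these differences.

Going by these compounds, how much of the step belongs to the one-carbon link and how much to the methoxy group remains open, and 4-methoxyphenyl or unsubstituted benzyl would separate the two. Also open, on these data alone, is how furan-2-yl or an amine would read at this position.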